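Isobutyl for sec-butyl on the amine nitrogen of the core

A few compounds are considered here, and "the series" means these few. Any claim that something is new, unique, unknown or untested is made for them only; others in the source may bear on it.

In a functional assay on CHO-K1 cells (Cricetulus griseus) for inhibition, read by MTT assay, with a stated time of 72 h (on this read-out lower numbers stand for stronger inhibition and higher numbers for weaker inhibition), compound 1 `CCC(C)NC(=C\C(=O)/C=C/c1ccc(O)c(OC)c1)/C=C/c1ccc(O)c(OC)c1` reaches only a limit of the assay, > 25000 nM, and gives no number. Compound 1 therefore sits at the limit of > 25000 nM in this assay, at which 1 of the 2 values shown sits. Compound 2 `CC(C)CNC(=C\C(=O)/C=C/c1ccc(O)cc1)/C=C/c1ccc(O)cc1` gives 17900 nM in this assay; it differs from compound 1 in more than one place, so its value shows no more than where a compound with isobutyl on the nitrogen can sit. Within the data shown here, compound 3 `COc1cc(/C=C/C(=O)/C=C(/C=C/c2ccc(O)c(OC)c2)NCC(C)C)ccc1O` carries the change (isobutyl in place of sec-butyl on an amine nitrogen), and no measured step of this kind exists. The step of a number no higher from compound 1 to compound 3 (the limit leaves the size open) is expected to stay within the scatter. Compound 3 is estimated at 25000 nM in this assay, with a range from 8000 nM to 80000 nM.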

Compound 3, half-maximal inhibitory concentration: > 25000 nM
Compound 3: no number, only a limit; the forecaster's own chance of this, stated with the estimate: 60%; the middle value lies on the limit itself.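

Among these compounds, compound 1 and compound 3 both stand only at a limit of this assay, so no step between them can be read. The compounds shown leave open what size of step isobutyl in place of sec-butyl on an amine nitrogen gives in this assay.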